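The source may hold more compounds than are shown below. What is called first, only, known or untested is meant among the compounds shown, and "the series" means these compounds.

Measured so far:
compound 1 `COc1cc(N2C(=O)C(Oc3ccccc3)C2c2ccc(SC)cc2)cc(OC)c1OC` — 336 nM
compound 2 `COc1ccc(C2CC(=O)N2c2cc(OC)c(OC)c(OC)c2)cc1` — 65 nM

Both numbers come from a functional assay on HT-29 cells (Homo sapiens) for inhibition, read by sulforhodamine B assay, with a stated time of 72 h; a higher number here means a weaker inhibitor, a lower number a stronger inhibitor. Compound 2 stands at the lower of the two numbers; compound 1 gives the higher one, and the gap between them lies beyond the usual scatter. For the measured compounds named here, no pair of measured compounds differs in a single place, so there is no measured step to lean on.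

Compound 3 `COc1cc(N2C(=O)CC2c2ccc(SC)cc2)cc(OC)c1OC` is not yet measured. It differs from compound 2 in one place:
methylsulfanyl in place of methoxy on an aromatic carbon
The group that leaves and the group that enters each carry the same count of heavy atoms and one hydrogen-bond acceptor, with no ring and no charge.

Going by the values given here, with no measured step for this kind of change, the expectation is a small step, in either direction, not beyond the scatter. The step from compound 2 to compound 3 is expected to be a 1.2-fold higher number from compound 2 to compound 3 (0.09 log units; within the scatter). Compound 3 is estimated at 80 nM in this assay, with a range from 30 nM to 250 nM.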

Compound 3, half-maximal inhibitory concentration: 108 nM
Compound 3: the middle estimate sits 1.4-fold (0.13 log units) below what was measured, and the stated range covers the measured number.
By their numbers in this assay, from the lowest: compounds 2 and 3 (each within the scatter of the next); then compound 1.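

In this assay, methylsulfanyl and methoxy on an aromatic carbon para to a large group read alike, with a 1.7-fold higher number from compound 2 to compound 3 (0.22 log units; within the scatter) and no step beyond the scatter. Compound 3 also opens a second comparison on a saturated ring carbon, where hydrogen in place of phenoxy gives a 3.1-fold lower number from compound 1 to compound 3 (0.49 log units; beyond the scatter) and so shows that the phenoxy group of compound 1 is not required for a value of this order in this series. Nothing available explains either step.

Open, going by these compounds, is whether other groups at the same aromatic carbon, such as ethoxy, chlorine or a dimethylamino group, would read like these two. Also open, on these data alone, is how a hydroxyl group or an amine on the saturated ring carbon would compare with hydrogen and phenoxy.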